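The source may report more compounds than this note shows. Statements on the series, on what has been measured and on what is new or still open speak of the compounds shown alone.

Compound 1 `O=C(/C=C/c1ccc2c(c1)B(O)OC2)c1ccccc1` — in an ADME assay on L929 cells (Mus musculus) for cytotoxicity, read by resazurin assay, with a stated time of 72 h (on this read-out higher numbers stand for weaker inhibition and lower numbers for stronger inhibition), compound 1 gives > 10 ug/mL, which is a limit of the assay rather than a number.
Compound 2 `O=C(/C=C/c1ccc2c(c1)B(O)OC2)c1ccccc1O` — in this assay compound 2 gives > 10 ug/mL, again a limit.
Compound 3 `Cn1cccc1C(=O)/C=C/c1ccc2c(c1)B(O)OC2` — in this assay compound 3 gives > 10 ug/mL, also a limit.

Compound 3 therefore stands exactly where the other two stand: at the limit of > 10 ug/mL in this assay, at which 3 of the 3 values shown sit. None of the three gives a number, so none can be set apart from the others.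

Compound 4 `O=C(/C=C/c1ccc2c(c1)B(O)OC2)c1ccc(Cl)cc1` is the next compound. The change from compound 3 is 4-chlorophenyl in place of 1-methyl-1H-pyrrol-2-yl on a carbonyl carbon. The measured steps that touch the same position are a step that the two limits leave unreadable from compound 1 to compound 3 and a step that the two limits leave unreadable from compound 2 to compound 3, and the remaining one, a step that the two limits leave unreadable from compound 1 to compound 2, is in the same state. Every step among the measured compounds is thus unreadable in size and direction, because all three values sit at the limit of > 10 ug/mL in this assay, at which 3 of the 3 values shown sit. There is no basis for expecting a step beyond the scatter in this assay, and the most likely outcome is that compound 4 is again reported only as a limit.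

Compound 4 is expected to give 15 ug/mL in this assay, within a range from 8 ug/mL to 40 ug/mL. The step that this estimate implies, a step that the limit leaves unreadable from compound 3 to compound 4, is expected to be no more than scatter.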

Compound 4, half-maximal inhibitory concentration: > 10 ug/mL
Compound 4: only a limit was reported; the forecaster's own chance of this, stated with the estimate: 80%; the middle value is on the limit's open side.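

In this assay compound 4 gives > 10 ug/mL as a limit and not a number. Going by these compounds alone, no step from compound 1, compound 2 or compound 3 to compound 4 can be read, in size or in direction: the limit of > 10 ug/mL in this assay, at which 4 of the 4 values shown sit. The compounds shown leave open at what concentration any of them affects these cells, and whether changing the group on the carbonyl carbon makes any difference.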